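Chloro for Methoxy: Two Measured Steps and One Expected

The source may report more compounds than this note shows. Statements on the series, on what has been measured and on what is new or still open speak of the compounds shown alone.

In a functional assay on ECa-109 cells (Homo sapiens) for inhibition, read by MTT assay, with a stated time of 72 h (a higher number here means a weaker inhibitor, a lower number a stronger inhibitor), compound 2 `COc1ccc(Cn2cc(CSC(=S)N3CCN(C(=O)OCc4ccccc4)CC3)nn2)cc1` gives 58300 nM.
Compound 3 `COc1ccc(Cn2cc(CSC(=S)N3CCN(C(=O)OC(C)(C)C)CC3)nn2)cc1` gives 36800 nM.
Compound 1 `O=C(OCc1ccccc1)N1CCN(C(=S)SCc2cn(Cc3ccc(Cl)cc3)nn2)CC1` gives > 128000 nM, which is a limit of the assay and not a number.

The change chloro in place of methoxy on an aromatic carbon gives an at least 2.1-fold higher number from compound 2 to compound 1 (0.34 log units; beyond the scatter); the value of compound 1 sits at the limit (the limit of > 128000 nM in this assay, at which 1 of the 3 values shown sits). The two cores differ by tert-butyl in place of benzyl on an oxygen next to a carbonyl group, and that change gives a 1.6-fold lower number from compound 2 to compound 3 (0.20 log units; within the scatter), a step that stays within the scatter.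

Compound 4 `CC(C)(C)OC(=O)N1CCN(C(=S)SCc2cn(Cc3ccc(Cl)cc3)nn2)CC1` carries the same change as compound 1, (chloro in place of methoxy on an aromatic carbon), now on the core of compound 3. Because compound 2 to compound 1 gave an at least 2.1-fold higher number from compound 2 to compound 1 (0.34 log units; beyond the scatter), a step of similar size is expected here, a 2.4-fold higher number from compound 3 to compound 4 (0.39 log units; beyond the scatter). Compound 4 is therefore estimated at 90000 nM, with a range from 45000 nM to 200000 nM, and a real chance that only a limit is reported.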

Compound 4, half-maximal inhibitory concentration: > 128000 nM
Compound 4: no number, only a limit; the forecaster's own chance of this, stated with the estimate: 35%; middle value at least 1.4-fold (0.15 log units) away from the limit.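

In this assay, chloro in place of methoxy on an aromatic carbon gives a weaker inhibitor on both cores, and on the core of compound 3 the change gives an at least 3.4-fold higher number from compound 3 to compound 4 (0.54 log units; beyond the scatter). Compound 4 gives > 128000 nM, which is a limit of the assay and not a number. The direction therefore carries from one core to the other, but the true sizes of the two steps stay unknown, and the step between compound 1 and compound 4 cannot be read: the same change on two cores in this assay, an at least 2.1-fold higher number (0.34 log units; beyond the scatter) from compound 2 to compound 1 and an at least 3.4-fold higher number (0.54 log units; beyond the scatter) from compound 3 to compound 4; the limit leaves it open whether they differ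

The compounds shown leave open how a fluoro, a methyl or a nitrile would read in place of the methoxy or chloro. Also open, as far as these compounds go, is whether a longer chain in place of tert-butyl or benzyl would change the numbers in this assay.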